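Vero cell tolerance across an aryl replacement

The source may report more compounds than this note shows. Statements on the series, on what has been measured and on what is new or still open speak of the compounds shown alone.

Compound 1 `COc1nc(-c2ccncc2)ccc1[C@@H](c1ccccc1)[C@@](O)(CCN(C)C)c1cccc2ccccc12` and compound 3 `COc1nc(-c2ccc(Cl)cc2)ccc1[C@@H](c1ccccc1)[C@@](O)(CCN(C)C)c1cccc2ccccc12` share one core. In a toxicity assay on Vero cells (Chlorocebus sabaeus) for cytotoxicity (a lower number here means that less compound is tolerated, a higher number that more compound is tolerated), compound 1 gives > 50 ug/mL, which is a limit of the assay rather than a number. Compound 2 `COc1ncc(-c2ccccc2)cc1[C@@H](c1ccccc1)[C@@](O)(CCN(C)C)c1cccc2ccccc12` in this assay gives > 50 ug/mL, again only a limit. For the measured compounds named here, both measured values thus sit at the limit of > 50 ug/mL in this assay, at which 2 of the 2 values shown sit, so no step between measured compounds can be sized. The change from compound 1 to compound 3 is 4-chlorophenyl in place of pyridin-4-yl on an aromatic carbon. No step beyond the scatter is expected in this assay. Compound 3 is estimated at 45 ug/mL, between 20 ug/mL and 90 ug/mL. That expectation means a step of an at least 1.1-fold lower number from compound 1 to compound 3 (0.04 log units; that floor lies within the scatter).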

Compound 3, half-maximal cytotoxic concentration: > 50 ug/mL
Compound 3 ended at the assay's limit; the forecaster's own chance of this, stated with the estimate: 60%; middle value at least 1.1-fold (0.04 log units) from the limit.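

No step can be read from compound 1 to compound 3 in this assay, because both values are limits: the limit of > 50 ug/mL in this assay, at which 3 of the 3 values shown sit.

Still open, on these data alone, is whether 4-chlorophenyl in place of pyridin-4-yl shifts tolerance at all, and at what concentration compound 1, compound 2 or compound 3 becomes cytotoxic.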